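The source may hold more compounds than are shown below. What is called first, only, known or untested is meant among the compounds shown, and "the series" means these compounds.

Working notes on the series. Compound 1 `N#CC1=C(N)N(c2ccc(S(N)(=O)=O)cc2)C2=C(CCCC2)C1/C=C/c1ccccc1` and compound 2 `N#CC1=C(N)N(c2ccc(S(N)(=O)=O)cc2)C2=C(CCCC2)C1c1ccccc1Cl` have been measured in a functional assay on Ehrlich cells (Mus musculus) for cytotoxicity, read by trypan blue exclusion, with a stated time of 2 h, tested at 50 ug/mL; a lower number here means a weaker effect, a higher number a stronger effect of the compound at the concentration tested. Compound 1 gives 90%, the highest of the two numbers; compound 2 gives 5%. Within the data shown here, the only step between measured compounds, 2-chlorophenyl in place of 2-phenylethenyl on a saturated ring carbon, is a number 85 percentage points lower from compound 1 to compound 2 (beyond the scatter), a large loss.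

Compound 3 `N#CC1=C(N)N(c2ccc(S(N)(=O)=O)cc2)C2=C(CCCC2)C1c1ccc(Cl)cc1Cl` is not yet measured. It differs from compound 1 in one place: 2,4-dichlorophenyl in place of 2-phenylethenyl on a saturated ring carbon. The step from compound 1 to compound 2 bears directly on this change, since in both cases the 2-phenylethenyl group on the saturated ring carbon is replaced by a chlorine-bearing phenyl ring; the entering group here carries a second chlorine. That one measured step is large, and nothing in the data points to the 2,4-dichlorophenyl group behaving differently from the 2-chlorophenyl group. A large downward step in this assay is therefore expected for compound 3, a number 80 percentage points lower from compound 1 to compound 3 (beyond the scatter) being the expected size. Compound 3 is estimated at 10%, with a range from 0% to 35%.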

Compound 3, a percentage reported as activity, at one concentration (the size of the read-out at that concentration, not a potency): 50%
Estimate against measurement, compound 3: 40 percentage points below, and the stated range ends below it.
By their numbers in this assay, from the lowest: compound 2; then compound 3; then compound 1.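

In this assay, the saturated ring carbon of the six-membered non-aromatic ring does not respond to every chlorine-bearing phenyl ring in the same way: exchanging 2-phenylethenyl for 2,4-dichlorophenyl gives a number 40 percentage points lower from compound 1 to compound 3 (beyond the scatter) and still leaves a clear loss, but not the near-complete one seen with 2-chlorophenyl. The aromatic ring entering at this carbon can therefore be tuned, and the added chloro group recovers a large part of the effect, with a number 45 percentage points higher from compound 2 to compound 3 (beyond the scatter) for a change of a single hydrogen on an aromatic carbon. No measurement bears on why the added chloro group has this effect.

The compounds shown do not separate the contribution of the added chloro group from the presence of two chloro groups together, a question that 4-chlorophenyl and unsubstituted phenyl would address, nor do they show whether a methoxy or amino group in place of that chloro group would serve equally well. They also leave open whether the double bond of 2-phenylethenyl matters, which a saturated 2-phenylethyl chain at the same carbon would test, and every reading here remains one at a single concentration rather than a potency.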